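The source may hold more compounds than are shown below. What is called first, only, known or untested is meant among the compounds shown, and "the series" means these compounds.

Measured in a physicochemical assay, read by spectrophotometry, with a stated time of 20 min; on this read-out higher numbers stand for weaker inhibition and lower numbers for stronger inhibition:
- compound 1 `CC(C)(C)c1ccc(-c2oc3cc(O)cc(O)c3c(=O)c2O)cc1`: 709000 nM
- compound 2 `O=C(/C=C/c1ccc(Cl)cc1)c1ccccc1O`: 6100000 nM
- compound 3 `O=C(/C=C/C=C/c1ccccc1)c1ccccc1O`: 7130000 nM

Compound 1 has the lowest number of the three, and so the strongest inhibition, with compound 2 and compound 3 both higher by more than the scatter. Compound 4 `CN(C)c1ccc(-c2oc3cc(O)cc(O)c3c(=O)c2O)cc1` keeps the core of compound 1 but has dimethylamino in place of tert-butyl on an aromatic carbon, para to a large group: dimethylamino in place of tert-butyl on an aromatic carbon. For the measured compounds named here, no measured pair of compounds differs at one place only, so this expectation rests on the structural change alone. A moderate move towards a lower number in this assay is expected, though a change within the scatter remains possible. The estimated step is a 2.0-fold lower number from compound 1 to compound 4 (0.31 log units; beyond the scatter). For compound 4 the expected value is 350000 nM, within an estimated range of 70000 nM to 1200000 nM.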

Compound 4, half-maximal inhibitory concentration: 612000 nM
Estimate against measurement, compound 4: 1.7-fold (0.24 log units) below; the range from low to high includes it.
By their numbers in this assay, from the lowest: compounds 4 and 1 (each within the scatter of the next); then compounds 2 and 3 (each within the scatter of the next).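

In this assay, replacing tert-butyl with dimethylamino on an aromatic carbon, para to a large group, gives a 1.2-fold lower number from compound 1 to compound 4 (0.06 log units; within the scatter). At this place, then, all-carbon tert-butyl and dimethylamino, which brings a nitrogen and a hydrogen-bond acceptor, cannot be told apart on the core of compound 1. No available evidence explains this result. As far as these compounds go, it remains open whether a carboxylic acid or a primary amine at this place would give a number distinct from both, and whether a longer chain would do so.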